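Diyne alcohols: removing the terminal vinyl from compound 3

A few compounds are considered here, and "the series" means these few. Any claim that something is new, unique, unknown or untested is made for them only; others in the source may bear on it.

Compound 3 `C=CCCCCCCCC#CC#CCO` gives the lowest number among the three measured compounds in a functional assay on HCT-15 cells (Homo sapiens) for cytotoxicity (a lower number here means that less compound is needed, a higher number that more compound is needed for the effect), with 3.32 ug/mL. Compound 2 `C=CCCCCCCCC#CC#CC(O)CC(C)=O` gives 4.18 ug/mL, and the step of a 1.3-fold lower number from compound 2 to compound 3 (0.10 log units; within the scatter) lies within the scatter, so these two compounds cannot be ordered against each other. Within the data shown here, compound 1 `C=CCCCCCC#CC#CCO` gives 12.9 ug/mL; the step of a 3.9-fold lower number from compound 1 to compound 3 (0.59 log units; beyond the scatter) is the only step that clears the scatter.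

Compound 4 `CCCCCCCC#CC#CCO` has not yet been measured in this assay. Against compound 3 the change is hydrogen in place of vinyl on a saturated chain carbon, seven bonds along the chain from a triple-bonded carbon. Among the measured compounds shown here, the one measured step that bears on this end of the chain is a 3.9-fold lower number from compound 1 to compound 3 (0.59 log units; beyond the scatter), where the chain grew by the same count that is now removed; the present change also removes the double bond, for which no step gives guidance. The step from compound 2 to compound 3 concerns a different position and is within the scatter, so it says nothing about this change. A higher number, roughly undoing the move from compound 1 to compound 3, is therefore expected, that is a step of a 3.0-fold higher number from compound 3 to compound 4 (0.48 log units; beyond the scatter). For compound 4 the expected value in this assay is 10 ug/mL, with a range from 4 ug/mL to 25 ug/mL.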

Compound 4, concentration for half-maximal effect: 5.9 ug/mL
The estimate for compound 4 lay 1.7-fold (0.23 log units) above the measured number; measured number inside the range.
By their numbers in this assay, from the lowest: compounds 3, 2 and 4 (each within the scatter of the next); then compound 1.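

Hydrogen in place of vinyl on a saturated chain carbon, seven bonds along the chain from a triple-bonded carbon, gives in this assay a 1.8-fold higher number from compound 3 to compound 4 (0.25 log units; within the scatter) and so leaves compound 3 and compound 4 unordered, which means the terminal vinyl is not shown to matter on this longer chain. Ethyl in place of vinyl on a saturated chain carbon, five bonds along the chain from a triple-bonded carbon, gives a 2.2-fold lower number from compound 1 to compound 4 (0.34 log units; beyond the scatter) as a modest step, so the vinyl-bearing compound 1 stands apart from compound 4, and the earlier chain-growth step is no longer the only single change that separates compound 1 from the rest of the series. No data shown here explain either step.

The compounds shown leave open whether the vinyl end matters only on the shorter chain, since that reading rests on one pair and compound 3 goes against any general role for the vinyl. Also open, on these data alone, is how a longer saturated chain, or an amine or a carboxylic acid in place of the hydroxyl, would read in this assay against these numbers.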